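The source may report more compounds than this note shows. Statements on the series, on what has been measured and on what is new or still open speak of the compounds shown alone.

Measured so far:
compound 1, `O=C(Nc1cccc(C(F)(F)F)c1)N[C@H]1CC[C@H](Oc2ccc(C(F)(F)F)cc2)CC1`: 460 nM
compound 2, `CSc1ccc(NC(=O)N[C@H]2CC[C@H](Oc3ccc(F)cc3)CC2)cc1`: > 20000 nM

In a functional assay on CRL2813 cells (Homo sapiens) for cytotoxicity, read by sulforhodamine B assay, with a stated time of 5 days (a lower number here means a stronger inhibitor, a higher number a weaker inhibitor), compound 1 gives 460 nM. For compound 2 the result in this assay is a limit of the assay and not a number: compound 2 reports > 20000 nM. Among the compounds with values here, compound 2 thus stands at the limit of > 20000 nM in this assay, at which 1 of the 2 values shown sits, and it differs from compound 1 in more than one place, so the two values show only that compound 1 lies within the measurable range while compound 2 does not.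

The untested compound 3, `O=C(Nc1cccc(I)c1)N[C@H]1CC[C@H](Oc2ccc(F)cc2)CC1`, keeps the core of compound 2 and changes one part: 3-iodophenyl in place of 4-(methylsulfanyl)phenyl on an amide-type nitrogen. Within the data shown here, no measured pair isolates this change, so its size is not known from the data. The writer expects a step toward stronger inhibition, beyond the scatter, because compound 1, which also carries a halogen-bearing phenyl on the urea nitrogen, gives 460 nM. Compound 3 is expected to give about 3000 nM in this assay, in a range from 600 nM to 20000 nM. That estimate means an expected step of an at least 6.6-fold lower number from compound 2 to compound 3 (0.82 log units; beyond the scatter).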

Compound 3, half-maximal inhibitory concentration: 5200 nM
Estimate against measurement, compound 3: 1.7-fold (0.24 log units) below, and the stated range covers the measured number.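

In this assay, 3-iodophenyl in place of 4-(methylsulfanyl)phenyl on the amide-type nitrogen gives an at least 3.8-fold lower number from compound 2 to compound 3 (0.58 log units; beyond the scatter). Within the data shown here, this is the first pair that differs in one place only, and it shows that the group on this nitrogen can by itself bring the compound into the measurable range while the rest of the structure stays the same. Compound 2 stands at a limit of the assay and not at a number, so the step has a lower bound only and its full size stays unknown: the limit of > 20000 nM in this assay, at which 1 of the 3 values shown sits.

Among these compounds, the single pair cannot separate what the entering iodine contributes from what the departing methylsulfanyl group removes, and it leaves open whether chlorine, a nitrile, an amine or a carboxylic acid on the phenyl ring at this nitrogen would give a similar step. It also leaves open whether 3-iodophenyl would produce a step of the same size on a core carrying a different group in place of the fluorine.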